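This account rests on a few compounds, and the source may have more. Where it says the series, first, only, none or still open, it means among the compounds named here.

Working notes on the series.

The core shared by these compounds is shown in compound 1, `CCCNc1ncnc2c1cnn2-c1ccccc1`. Going by the values given here, both values known so far in a functional assay on G-361 cells (Homo sapiens) for cytotoxicity, read by sulforhodamine B assay (on this read-out lower numbers stand for stronger inhibition of growth and higher numbers for weaker inhibition of growth), are limits of the assay rather than numbers. In this assay compound 1 gives > 100000 nM, a limit. Compound 2, `CCN(CC)c1nc(C)nc2c1cnn2-c1ccccc1`, also returns only a limit in this assay, namely > 100000 nM. Among the compounds with values here, compound 1 therefore stands where every value so far stands, at the limit described by the limit of > 100000 nM in this assay, at which 2 of the 2 values shown sit; no measured step can be drawn, as no two compounds differ in a single place.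

The next compound, compound 3, `CCCNc1nc(CC)nc2c1cnn2-c1ccccc1`, differs from compound 1 by ethyl in place of hydrogen on an aromatic carbon between two ring nitrogen atoms of the six-membered aromatic ring, meta to the propylamino group. With both known values sitting at the limit, no direction of step can be read from the data, and nothing beyond the scatter is expected. Compound 3 is expected to give about 100000 nM in this assay, with a range from 30000 nM to 300000 nM, which corresponds to an expected step of a number no higher from compound 1 to compound 3 (the limit leaves the size open). Most likely compound 3 too will come back as a limit.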

Compound 3, concentration for 50% growth inhibition: 2200 nM
Compound 3: the middle estimate sits 45-fold (1.66 log units) above what was measured; measured number below the stated range.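

Going by these compounds alone, the position between two ring nitrogen atoms, meta to the propylamino group, is the first place where a change gives a measurable response: in this assay, ethyl in place of hydrogen on an aromatic carbon gives an at least 45-fold lower number from compound 1 to compound 3 (1.65 log units; beyond the scatter). From the compounds shown here alone, for compound 1 the value remains a limit, > 100000 nM, so the true size of this step stays open and only its direction and minimum size can be read. Compound 3 is therefore the only compound shown with a number in this assay, and the others remain at the limit: the limit of > 100000 nM in this assay, at which 2 of the 3 values shown sit.

The compounds shown leave open whether the gain needs a chain of this length, since a methyl, a propyl or a longer chain, or a group such as an amine or a carboxylic acid, at this same carbon would be needed to define what the position tolerates. Going by these compounds, compound 2 differs from compound 3 in more than one place, so no step can be read for it, and whether ethyl has the same effect with a group other than propylamino also remains open.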